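Chain extension at the amino side chain of compound 2

The compounds below may be only part of what the source reports. "The series", "measured", "known", "first", "only" and "open" are said of these compounds alone.

Compound 2 `NCCNc1c(C(=O)NCc2ccc(F)cc2)nc(Br)c2cccnc12` stands at the top of the two numbers available: in a functional assay on MDA-MB-435 cells (Homo sapiens) for cytotoxicity, read by MTT assay, with a stated time of 72 h (on this read-out lower numbers stand for stronger inhibition and higher numbers for weaker inhibition), compound 2 gives 12000 nM. Going by the values given here, the only other measured member, compound 1 `N[C@H]1CC[C@H](Nc2c(C(=O)NCc3ccc(Cl)cc3)nc(Br)c3cccnc23)CC1`, differs from compound 2 in more than one place, so no single step connects them; in this assay compound 1 gives 1000 nM, a markedly lower number, beyond the scatter.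

Compound 3 `NCCCCCCNc1c(C(=O)NCc2ccc(F)cc2)nc(Br)c2cccnc12` has not been measured. It differs from compound 2 by 4-aminobutyl in place of amino on a saturated chain carbon, two bonds along the chain from a nitrogen on an aromatic ring. Among the compounds with values here, no measured pair shows this change on its own, so its direction is open. Compound 1, which carries a different amine-bearing group on the ring nitrogen together with a different halogen on the benzyl group, gives 1000 nM; that number suggests that an amine side chain other than the shortest one is tolerated, but the second difference in compound 1 prevents assigning the gain to the side chain alone.

For compound 3 a modest improvement is expected, a step of a 2.4-fold lower number from compound 2 to compound 3 (0.38 log units; beyond the scatter) in this assay. The estimate for compound 3 is 5000 nM, with an expected range from 1200 nM to 20000 nM.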

Compound 3, half-maximal inhibitory concentration: 6000 nM
The estimate for compound 3 lay 1.2-fold (0.08 log units) below the measured number, within the range that was stated.
By their numbers in this assay, from the lowest: compound 1; then compounds 3 and 2 (each within the scatter of the next).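

Going by these compounds alone, this is the first pair that differs in one place, so the side chain can now be read directly. With 4-aminobutyl in place of amino on a saturated chain carbon, two bonds along the chain from a nitrogen on an aromatic ring, this assay shows a 2.0-fold lower number from compound 2 to compound 3 (0.30 log units; within the scatter). The position therefore accepts (6-aminohexyl)amino in place of (2-aminoethyl)amino with the two numbers remaining within the scatter, and no measurement at hand offers an explanation for this result.

Still open, going by these compounds, is whether the number of compound 1, 1000 nM, belongs to its different amine-bearing group or to the different halogen on the benzyl group, a question that a compound carrying only one of these two differences could separate. Also open, on these data alone, is how a hydroxyl or a carboxylic acid in place of the terminal amine, or a still longer chain, would read in this assay.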